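From a benzyl chain to an arylamino arm

The compounds below may be only part of what the source reports. "The series", "measured", "known", "first", "only" and "open" are said of these compounds alone.

Three compounds share one core and differ only in the chain attached to the carbonyl. Compound 1 `Cc1nc2cnccc2n1CC1CCN(C(=O)CC(C)c2ccccc2)CC1` gives 12 nM in a functional assay (plasma) with Oryctolagus cuniculus as the target; a lower number here means a stronger inhibitor, a higher number a weaker inhibitor; compound 3 `Cc1nc2cnccc2n1CC1CCN(C(=O)CC(c2ccccc2)c2ccccc2)CC1` gives 7.6 nM; compound 2 `Cc1nc2cnccc2n1CC1CCN(C(=O)CCc2ccccc2)CC1` gives 60 nM, the highest number of the three, with steps to both others beyond the scatter: a 7.9-fold lower number from compound 2 to compound 3 (0.90 log units; beyond the scatter) and a 5.0-fold higher number from compound 1 to compound 2 (0.70 log units; beyond the scatter). Within those two, the numbers for compound 1 and compound 3 sit within the scatter of each other, a 1.6-fold lower number from compound 1 to compound 3 (0.20 log units; within the scatter).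

Compound 4 `COc1ccccc1N(C)CC(=O)N1CCC(Cn2c(C)nc3cnccc32)CC1` departs from compound 2 by (2-methoxyphenyl)(methyl)amino in place of benzyl on a saturated chain carbon bound to a carbonyl carbon. Within the data shown here, no measured step touches this position; the known steps all concern the chain carbon bound to the aromatic carbon, where added groups gave modest changes. They offer no direct guide, so a change of at most modest size in either direction is expected, with a wide range. The estimate for compound 4 is 40 nM (from 8 nM to 250 nM), meaning an expected step of a 1.5-fold lower number from compound 2 to compound 4 (0.18 log units; within the scatter).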

Compound 4, half-maximal inhibitory concentration: 14 nM
Compound 4: the middle estimate sits 2.9-fold (0.46 log units) above what was measured, and the stated range covers the measured number.
By their numbers in this assay, from the lowest: compounds 3, 1 and 4 (each within the scatter of the next); then compound 2.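

Among these compounds, putting (2-methoxyphenyl)(methyl)amino in place of benzyl on the saturated chain carbon bound to a carbonyl carbon gives a step beyond the scatter in this assay (a 4.3-fold lower number from compound 2 to compound 4 (0.63 log units; beyond the scatter)), so this position, which no earlier step touched, responds to change. Set against 1-phenylethyl at the same place, the group gives a step within the scatter (a 1.2-fold higher number from compound 1 to compound 4 (0.07 log units; within the scatter)), and the two compounds cannot be told apart in this read-out. Nothing measured here bears on why the number moves.

The compounds shown leave open which part of (2-methoxyphenyl)(methyl)amino carries the step, as its methoxy, its methyl and its amino nitrogen all enter together. Going by these compounds, how a plain phenylamino group would read at this place also stays open.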